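Thiophene-to-pyrrole swap at the aryl position of the imidazoline series

The compounds below may be only part of what the source reports. "The series", "measured", "known", "first", "only" and "open" are said of these compounds alone.

Measured so far:
compound 1 `c1cncc(-c2ccccc2OCC2=NCCN2)c1`: 158 nM
compound 2 `c1csc(-c2ccccc2OCC2=NCCN2)c1`: 15.9 nM

In a functional assay for activation of Alpha-1D adrenergic receptor (Homo sapiens), read by calcium flux (a higher number here means that more compound is needed for the effect, a lower number that less compound is needed), compound 2 gives the lowest of the two numbers; its nearest neighbour is compound 1, separated by a 9.9-fold lower number from compound 1 to compound 2 (1.00 log units; beyond the scatter). Going by the values given here, that step, thiophen-2-yl in place of pyridin-3-yl on an aromatic carbon, is the only measured change.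

Compound 3 `c1c[nH]c(-c2ccccc2OCC2=NCCN2)c1` is not yet measured. It differs from compound 2 by 1H-pyrrol-2-yl in place of thiophen-2-yl on an aromatic carbon. Among the compounds with values here, no measured pair shows this exact exchange. Within the data shown here, the one step on record, from compound 1 to compound 2, exchanges one aromatic ring for another at the same aromatic carbon and was beyond the scatter, so a change at this position can move this assay by a modest amount. Whether the pyrrole behaves more like the thiophene of compound 2 or the pyridine of compound 1 is not decided by the data. A number somewhat higher than that of compound 2 is expected for compound 3, estimated at 40 nM (range 10 nM to 160 nM), which would be a step of a 2.5-fold higher number from compound 2 to compound 3 (0.40 log units; beyond the scatter).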

Compound 3, half-maximal effective concentration: 6.31 nM
Compound 3: middle estimate off by 6.3-fold (0.80 log units), on the high side, and the stated range ends above it.
By their numbers in this assay, from the lowest: compound 3; then compound 2; then compound 1.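

Notes on the aryl position: in this assay this position now separates two five-membered aromatic rings with one hetero atom, with a 2.5-fold lower number from compound 2 to compound 3 (0.40 log units; beyond the scatter), so the earlier contrast between pyridin-3-yl and thiophen-2-yl was not the only one it can register. Against the pyridine, the pyrrole gives the widest step in the series, a 25-fold lower number from compound 1 to compound 3 (1.40 log units; beyond the scatter), and compound 3 now has the lowest number of the three. The exchange replaces sulfur with nitrogen and, by the computed counts, brings 1 hydrogen-bond donor and 0 hydrogen-bond acceptors where thiophen-2-yl had 0 and 1, but no measurement links either difference to the shift in the number.

Going by these compounds, it remains open whether the amide-free ring hydrogen on nitrogen of 1H-pyrrol-2-yl is tied to the lower number, a question that 1-methylpyrrol-2-yl or furan-2-yl would address directly. Also open, on these data alone, is how far the trend extends to a different attachment point, as in 1H-pyrrol-3-yl, or to a pyrrole carrying a methyl or chlorine substituent on the shared core.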